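The compounds below may be only part of what the source reports. "The series", "measured", "known", "first", "only" and "open" are said of these compounds alone.

Measured in a functional assay on MCF7 cells (Homo sapiens) for cytotoxicity, read by MTT assay, with a stated time of 96 h; on this read-out higher numbers stand for weaker inhibition and lower numbers for stronger inhibition:
- compound 1 `COc1cc(C(=O)c2cn(-c3ccccc3)cc2-c2ccccc2[N+](=O)[O-])cc(OC)c1OC`: 49 nM
- compound 2 `COc1ccccc1-c1cn(-c2ccccc2)cc1C(=O)c1cc(OC)c(OC)c(OC)c1`: 190 nM

In this assay, going by the values given here, compound 2 gives 190 nM, the higher of the two numbers so far, and its only comparison is with compound 1 at 49 nM.

The next compound is compound 3 `COc1ccc(Br)cc1-c1cn(-c2ccccc2)cc1C(=O)c1cc(OC)c(OC)c(OC)c1`, with the change (bromo in place of hydrogen on an aromatic carbon). In words, this is bromo in place of hydrogen on an aromatic carbon, taking 2-methoxyphenyl to 5-bromo-2-methoxyphenyl.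

Among the compounds with values here, one measured step bears on this, and only loosely: a 3.9-fold higher number from compound 1 to compound 2 (0.59 log units; beyond the scatter). It is modest but beyond the scatter, and it shows that a methoxy in place of nitro on an aromatic carbon can shift the number. Within the data shown here, no measured compound carries bromo, so neither the size nor the direction of the new step is established, and the earlier step serves only as a rough guide to scale.

The expected step is a 1.3-fold lower number from compound 2 to compound 3 (0.10 log units; within the scatter), which is estimated to stay within the scatter, with no firm direction. For compound 3 the estimated value is 150 nM, with an expected range from 40 nM to 550 nM.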

Compound 3, half-maximal inhibitory concentration: 2200 nM
Compound 3: the middle estimate sits 15-fold (1.17 log units) below what was measured; the measured number lies above the stated range.
By their numbers in this assay, from the lowest: compound 1; then compound 2; then compound 3.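

In this assay, a bromo on an aromatic carbon, para to a methoxy group and meta to a large group, gives a 12-fold higher number from compound 2 to compound 3 (1.06 log units; beyond the scatter), a large step that exceeds the modest 3.9-fold higher number from compound 1 to compound 2 (0.59 log units; beyond the scatter). This position is therefore not indifferent to substitution: a single added heavy atom here moves the number further than exchanging nitro for methoxy did, and the direction is towards weaker inhibition. The combined replacement of 2-nitrophenyl by 5-bromo-2-methoxyphenyl gives a 45-fold higher number from compound 1 to compound 3 (1.65 log units; beyond the scatter), and nothing available on these compounds accounts for the effect of the bromo.

On these data alone, it remains open whether the loss is specific to bromo or would also appear with a smaller group at the same carbon, such as fluoro, chloro or methyl, or with a hydroxyl or an amine there. As far as these compounds go, it is equally open whether a bromo at this carbon would have a similar effect alongside the nitro of compound 1 in place of the methoxy of compound 2, so the step cannot yet be treated as independent of its neighbouring substituent.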